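Homolog of the oxime ether on the cytidine triphosphate

A few compounds are considered here, and "the series" means these few. Any claim that something is new, unique, unknown or untested is made for them only; others in the source may bear on it.

The series is followed in an in vitro functional assay on 1321-N1 cells for agonist activity at P2Y purinoceptor 6 (Homo sapiens), read by scintillation proximity assay and inositol phosphate accumulation, with a stated time of 30 min; a lower number here means that less compound is needed, a higher number that more compound is needed for the effect. Two compounds have numbers. Compound 1 `O=c1[nH]/c(=N\OCc2ccccc2)ccn1[C@@H]1O[C@H](COP(=O)(O)OP(=O)(O)OP(=O)(O)OP(=O)(O)O[C@H]2O[C@H](CO)[C@@H](O)[C@H](F)[C@H]2O)[C@@H](O)[C@H]1O` gives 7510 nM in this assay. For the measured compounds named here, compound 2 `O=c1[nH]/c(=N\OCc2ccccc2)ccn1[C@@H]1O[C@H](COP(=O)(O)OP(=O)(O)OP(=O)(O)O)[C@@H](O)[C@H]1O` gives 230 nM in this assay, the lowest of the two numbers; compound 1 sits a long way higher, and no single-point step connects the two, so only the two values themselves are compared here. Compound 3 `O=c1[nH]/c(=N\OCCc2ccccc2)ccn1[C@@H]1O[C@H](COP(=O)(O)OP(=O)(O)OP(=O)(O)O)[C@@H](O)[C@H]1O` has not been measured. The change from compound 2 to compound 3 is benzyl in place of phenyl on a saturated chain carbon bound to an oxygen. With no measured step of this kind in the series, the expectation rests on compound 2 alone. The step of a 2.6-fold higher number from compound 2 to compound 3 (0.42 log units; beyond the scatter) is expected to be a moderate rise, slightly beyond the scatter, though a value within the scatter is possible. Compound 3 is accordingly estimated at 600 nM in this assay, within the range 150 nM to 2500 nM.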

Compound 3, half-maximal effective concentration: 1210 nM
Estimate against measurement, compound 3: 2.0-fold (0.30 log units) below, and the stated range covers the measured number.
By their numbers in this assay, from the lowest: compound 2; then compound 3; then compound 1.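

Benzyloxy to phenethyloxy gives the first single-point step in the series: in this assay there is a 5.3-fold higher number from compound 2 to compound 3 (0.72 log units; beyond the scatter). The position on the saturated chain carbon bound to an oxygen is therefore sensitive to this small extension, even with the phenyl ring retained, and the benzyloxy group gives the lower number of this pair.

On these data alone, a single step gives no trend, so it remains open whether a longer chain such as phenylpropyloxy would raise the number further. Also open, as far as these compounds go, is how a methoxy group, an amine or a carboxylic acid on the phenyl ring would read at this position. Nothing available explains the rise seen with phenethyloxy.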